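The compounds below may be only part of what the source reports. "The series", "measured", "known", "first", "only" and "open" are said of these compounds alone.

Measured so far in a functional assay on the whole organism (Abdomen, strain albino) for inhibition, with Mus musculus as the target, in the writhing test, with stated times of 1 h and 8 min, at a dose of 10 mg/kg by the oral route; a higher number here means more inhibition at the dose given (going by the name of the read-out), a lower number less inhibition:
compound 1, `CC1=CC[C@@H]2[C@@H](O[C@H](c3ccc(F)cc3)OC2(C)C)[C@@H]1O`, 40%
compound 2, `CC1=CC[C@@H]2[C@@H](O[C@H](c3ccc(Br)cc3)OC2(C)C)[C@@H]1O`, 33%
compound 3, `CC1=CC[C@@H]2[C@@H](O[C@H](c3ccc(Cl)c(Cl)c3)OC2(C)C)[C@@H]1O`, 14%

Compound 1 gives the highest of the three numbers. The nearest value comes with the step of a number 7 percentage points lower from compound 1 to compound 2 (within the scatter); compound 3 stands furthest from compound 1, beyond the scatter. Compound 4, `CC1=CC[C@@H]2[C@@H](O[C@H](c3ccc(C(F)(F)F)cc3)OC2(C)C)[C@@H]1O`, has not yet been measured in this assay. It differs from compound 1 in one place: trifluoromethyl in place of fluoro on an aromatic carbon. Among the measured compounds shown here, the only measured step that bears on a change at this aromatic carbon is the one from compound 1 to compound 2, which was within the scatter. No step exchanges fluoro for trifluoromethyl, so the size of the change is uncertain; on what is shown, a small loss or none beyond the scatter is expected. Compound 4 is therefore estimated at 30%, between 12% and 48%, an expected step of a number 10 percentage points lower from compound 1 to compound 4 (within the scatter).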

Compound 4, a percentage reported as inhibition, in the whole organism at one dose (the size of the read-out at that dose, not a potency): 52%
The estimate for compound 4 lay 22 percentage points below the measured number; the measured number lies above the stated range.
By their numbers in this assay, from the lowest: compound 3; then compounds 2 and 1 (each within the scatter of the next); then compound 4.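

In this assay, this aromatic carbon can shift the number beyond the scatter: trifluoromethyl gives a number 12 percentage points higher from compound 1 to compound 4 (beyond the scatter) and a number 19 percentage points higher from compound 2 to compound 4 (beyond the scatter), whereas the exchange of fluoro for bromo alone had stayed within it. The position therefore takes trifluoromethyl with no loss of inhibition at this dose. Nothing shown accounts for this gain. Open remains how an amine, a carboxylic acid or a methoxy group on this carbon would compare, and whether the gain with trifluoromethyl holds at other doses.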